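A few compounds are considered here, and "the series" means these few. Any claim that something is new, unique, unknown or untested is made for them only; others in the source may bear on it.

Among the compounds with values here, compound 2 `CC1=CC[C@@H]([C@@](C)(O)CCCC(C)(C)NC(=S)N/N=C\c2ccc(N(C)C)cc2)CC1` gives 3600 nM in a functional assay on OVCAR-3 cells (Homo sapiens) for cytotoxicity, read by sulforhodamine B assay; on this read-out higher numbers stand for weaker inhibition of growth and lower numbers for stronger inhibition of growth; compound 1 `CC1=CC[C@@H]([C@@](C)(O)CCCC(C)(C)NC(=S)N/N=C\c2ccccc2)CC1` gives 6970 nM, and the only step on the aromatic ring so far, a 1.9-fold lower number from compound 1 to compound 2 (0.29 log units; within the scatter), does not separate the two. Compound 3 `CC1=CC[C@@H]([C@@](C)(O)CCCC(C)(C)NC(=S)N/N=C\c2ccccc2[N+](=O)[O-])CC1` carries 2-nitrophenyl in place of 4-(dimethylamino)phenyl on a carbon with a double bond to nitrogen. That step bears only loosely here: it shows that a substituent on this ring, in the one case measured, moved the number by a 1.9-fold lower number from compound 1 to compound 2 (0.29 log units; within the scatter). Within the data shown here, no measured step covers 2-nitrophenyl. For compound 3 the expected step is a 1.5-fold higher number from compound 2 to compound 3 (0.18 log units; within the scatter), none beyond the scatter. The estimate for compound 3 is 5500 nM, ranging from 2000 nM to 15000 nM.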

Compound 3, concentration for 50% growth inhibition: 7390 nM
Beside the measured number, compound 3's estimate is 1.3-fold (0.13 log units) below it, within the range that was stated.
By their numbers in this assay, from the lowest: compounds 2, 1 and 3 (each within the scatter of the next, the first and the last beyond it).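

In this assay, within the data shown here, 2-nitrophenyl in place of 4-(dimethylamino)phenyl gives a 2.1-fold higher number from compound 2 to compound 3 (0.31 log units; beyond the scatter), the first step beyond the scatter, though only a modest one. Nitro in place of hydrogen on an aromatic carbon gives a 1.1-fold higher number from compound 1 to compound 3 (0.03 log units; within the scatter), which does not separate compound 3 from compound 1, so the readable difference at this position lies only between the two substituted rings.

Open, as far as these compounds go, is how a carboxylic acid or a primary amine on this ring would read, and whether the gap holds with nitro and dimethylamino elsewhere on the ring. No evidence on hand accounts for the step.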